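The compounds below may be only part of what the source reports. "The series", "measured", "known", "first", "only" and "open" are said of these compounds alone.

Of the compounds shown here, three share a core and have been tested in a functional assay on SK-MEL-2 cells (Homo sapiens) for cytotoxicity, read by sulforhodamine B assay, with a stated time of 48 h, tested at 1 uM; a higher number here means a weaker effect of the compound at the concentration tested, a lower number a stronger effect. Compound 1 `COc1cc(C)cc(-c2nn(CC#N)cc2-c2ccc(-c3cccc(C(C)=O)c3)nc2)c1` gives 22% in this assay. Compound 2 `Cc1cc(O)cc(-c2nn(CC#N)cc2-c2ccnc(-c3ccc(Oc4ccccc4)cc3)c2)c1` gives 6%. Compound 3 `COc1cc(C)cc(-c2nn(CC#N)cc2-c2ccnc(-c3ccc(N(C)C)cc3)c2)c1` gives 23%, the highest of the three numbers; compound 1 sits within the scatter of compound 3, while compound 2 lies beyond it, with a lower number and thus a stronger effect.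

The next compound, compound 4 `Cc1cc(O)cc(-c2nn(CC#N)cc2-c2ccnc(-c3ccc(N(C)C)cc3)c2)c1`, differs from compound 3 in one place: hydrogen in place of methyl on an oxygen on an aromatic ring. For the measured compounds named here, no measured pair shows this exact change alone, so its effect here is unknown. Going by the values given here, the only compound carrying the hydroxy group is compound 2, whose value of 6% in this assay is the strongest seen, but it also differs elsewhere, so it offers only a loose hint.

For compound 4 a modest move toward a stronger effect is expected, a step of a number 9 percentage points lower from compound 3 to compound 4 (within the scatter), which may still fall within the scatter. The estimate for compound 4 in this assay is 14%, with a range from 3% to 28%.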

Compound 4, a percentage reported as activity, at one concentration (the size of the read-out at that concentration, not a potency): 11%
The estimate for compound 4 lay 3 percentage points above the measured number; measured number inside the range.
By their numbers in this assay, from the lowest: compounds 2 and 4 (each within the scatter of the next); then compounds 1 and 3 (each within the scatter of the next).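

For the compounds shown here, changing methoxy to hydroxy on the 3-methoxy-5-methylphenyl group gives in this assay the first clean reading of this change: a number 12 percentage points lower from compound 3 to compound 4 (beyond the scatter) and so clears the usual scatter. With dimethylamino held in place, a hydrogen on this oxygen therefore goes with a stronger effect than a methyl. With the hydroxy group held in place, dimethylamino in place of phenoxy on an aromatic carbon gives a number 5 percentage points higher from compound 2 to compound 4 (within the scatter) and so cannot be told apart from scatter, and nothing measured here explains either step.

From the compounds shown here alone, it remains open whether an ethoxy group or an amino group in place of the hydroxy group would give a similar reading. Going by these compounds, it is also open whether the change from methoxy to hydroxy gives a step of similar size when phenoxy stands in place of dimethylamino.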